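Removing a fluoro from a cytotoxic indole sulfonamide

The source may report more compounds than this note shows. Statements on the series, on what has been measured and on what is new or still open speak of the compounds shown alone.

Compound 1 `O=C1C=CC(O)(c2cc3ccc(F)cc3n2S(=O)(=O)c2ccccc2)C=C1` is the parent here. In a functional assay on HCT-116 cells (Homo sapiens) (a higher number here means that more compound is tolerated, a lower number that less compound is tolerated), compound 1 gives < 10 nM, which is a limit of the assay rather than a number; the limit of < 10 nM in this assay, at which 1 of the 3 values shown sits, marks where it sits. Two relatives with a different sulfonyl substituent are also known: compound 2 `CC(C)c1cc(C(C)C)c(S(=O)(=O)n2c(C3(O)C=CC(=O)C=C3)cc3ccccc32)c(C(C)C)c1` gives 550 nM in this assay, and compound 3 `O=C1C=CC(O)(c2cc3ccccc3n2S(=O)(=O)c2ccc3ccccc3c2)C=C1` gives 370 nM. Compound 4 `O=C1C=CC(O)(c2cc3ccccc3n2S(=O)(=O)c2ccccc2)C=C1` has not been measured; its difference from compound 1 is hydrogen in place of fluoro on an aromatic carbon, on an aromatic carbon of a six-membered aromatic ring of carbon only. Among the compounds with values here, no measured step informs this change, so only a small shift in this assay is expected, if any beyond the scatter. Compound 4 is estimated at 15 nM, with a range of 4 nM to 60 nM, a step of an at least 1.5-fold higher number from compound 1 to compound 4 (0.17 log units; that floor lies within the scatter) from compound 1 that is expected to stay modest.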

Compound 4, concentration lethal to 50% of the cells: 116000 nM
For compound 4 the middle estimate is 7700-fold (3.89 log units) below the measured one; measured number above the stated range.
By their numbers in this assay, from the lowest: compounds 3 and 2 (each within the scatter of the next); then compound 4. At a limit, below all of these: compound 1.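

Within the data shown here, at this aromatic carbon, a single atom carries far more weight than the earlier compounds could reveal: in this assay, hydrogen in place of fluoro produces a very large change (an at least 11000-fold higher number from compound 1 to compound 4 (4.06 log units; beyond the scatter)). The sulfonyl group also counts, since phenyl in place of naphthalen-2-yl on a sulfonyl sulfur gives a large change too (a 310-fold higher number from compound 3 to compound 4 (2.50 log units; beyond the scatter)) on the core without fluoro. The value of compound 1 is a limit of the assay: the limit of < 10 nM in this assay, at which 1 of the 4 values shown sits.

From the compounds shown here alone, whether chloro or methoxy on this aromatic carbon would behave like fluoro or like hydrogen remains open, as does the effect of fluoro alongside the naphthalen-2-yl group.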